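Swapping Fluoro for Benzyloxy on a Shared Core

The source may report more compounds than this note shows. Statements on the series, on what has been measured and on what is new or still open speak of the compounds shown alone.

Compound 1 `Brc1ccc2ccn(CCN3CCCN4CCCCC4C3)c2c1` gives 3 nM in an assay on HEK293 cells for binding affinity to 5-hydroxytryptamine receptor 7 (Homo sapiens), read by radioligand binding; on this read-out lower numbers stand for stronger inhibition and higher numbers for weaker inhibition. Compound 2 `CN1CCCN(CCn2ccc3cc(Br)ccc32)CC1` gives 88 nM in this assay. Compound 3 `CN1CCCN(CCn2ccc3ccc(F)cc32)CC1` gives 288 nM in this assay.

Of these three numbers, compound 3 stands at the highest, meaning the weakest binding of the three. Its nearest neighbour on the scale is compound 2, whose value of 88 nM lies beyond the usual scatter from compound 3; the gap to compound 1 with 3 nM is wider still. Compound 2 and compound 3 share the same core and differ in which halogen sits on the aromatic ring and where it sits, so their two values show only that bromo at its place gives a lower number than fluoro at its place.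

Compound 4 `CN1CCCN(CCn2ccc3ccc(OCc4ccccc4)cc32)CC1` is compound 3 with one change: benzyloxy in place of fluoro on an aromatic carbon. The change keeps the core and the basic side chain and exchanges a single atom for a much larger group carrying one hydrogen-bond acceptor. Among the compounds with values here, no measured pair shows this exact swap, so the expectation rests on compound 3 alone, whose 288 nM is the starting point. A modest lowering of the number is expected, though a step within the scatter is just as plausible, and the estimated step from compound 3 to compound 4 is a 1.9-fold lower number from compound 3 to compound 4 (0.28 log units; within the scatter). Compound 4 is therefore expected to give about 150 nM, with a plausible range from 30 nM to 800 nM.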

Compound 4, inhibition constant: 182 nM
The estimate for compound 4 lay 1.2-fold (0.08 log units) below the measured number, and the stated range covers the measured number.
By their numbers in this assay, from the lowest: compound 1; then compound 2; then compounds 4 and 3 (each within the scatter of the next).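

In this assay, putting benzyloxy in place of fluoro gives a 1.6-fold lower number from compound 3 to compound 4 (0.20 log units; within the scatter), so the two compounds cannot be told apart on this read-out. Within the data shown here, this is the first pair here that differs in only one place, and it gives the first direct reading of this aromatic carbon: a single fluorine and a group of eight heavy atoms with its own six-membered aromatic ring give values within the usual scatter of each other. Nothing available accounts for this result, so it stands as an observation about these two compounds alone.

The compounds shown leave open how other groups on this same aromatic carbon would read, such as hydroxyl, methoxy, an amine or the longer phenethoxy, and so whether the match between fluoro and benzyloxy extends to anything beyond this one pair. Among these compounds, it also remains open whether the same exchange would give a similarly small step when made on a compound with the side chain of compound 1 rather than the one shared by compound 3 and compound 4.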